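Swapping Cyclobutyl for Diethylamino on the Sulfonyl Sulfur

The source may report more compounds than this note shows. Statements on the series, on what has been measured and on what is new or still open speak of the compounds shown alone.

Measured compounds:
Compound 1 `O=C([C@@H]1CCCN(S(=O)(=O)c2ccc(S(=O)(=O)C3CCC3)cc2)C1)N1CCC(F)(F)CC1` gives 9 nM
Compound 2 `O=C([C@@H]1CCCN(S(=O)(=O)c2ccc(S(=O)(=O)C3CC3)cc2)C1)N1CCC(F)(F)CC1` gives 26 nM
Compound 3 `CCN(CC)S(=O)(=O)c1ccc(S(=O)(=O)N2CCC[C@@H](C(=O)N3CCC(C(F)(F)F)CC3)C2)cc1` gives 320 nM

In a functional assay on MIA PaCa-2 cells (Homo sapiens) for inhibition, read by MTT assay, with a stated time of 7 days (on this read-out lower numbers stand for stronger inhibition and higher numbers for weaker inhibition), compound 1 gives the lowest number of the three. The step of a 2.9-fold higher number from compound 1 to compound 2 (0.46 log units; beyond the scatter) shows that exchanging the ring on the sulfonyl sulfur moves the read-out only modestly. Compound 4 `CCN(CC)S(=O)(=O)c1ccc(S(=O)(=O)N2CCC[C@@H](C(=O)N3CCC(F)(F)CC3)C2)cc1` differs from compound 1 as follows: diethylamino in place of cyclobutyl on a sulfonyl sulfur. Among the compounds with values here, no measured step covers exactly this change. Compound 3, which carries the same diethylamino group together with a different ring on the amide, gives 320 nM, a far higher number than compound 1. The change is therefore expected to raise the number, by roughly an 8.9-fold higher number from compound 1 to compound 4 (0.95 log units; beyond the scatter). Compound 4 is estimated at 80 nM, with a range from 20 nM to 400 nM.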

Compound 4, half-maximal inhibitory concentration: 16 nM
Estimate against measurement, compound 4: 5.0-fold (0.70 log units) above; the whole stated range lies above it.
By their numbers in this assay, from the lowest: compounds 1, 4 and 2 (each within the scatter of the next, the first and the last beyond it); then compound 3.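

On this sulfonyl sulfur, the open-chain diethylamino group matches the cyclobutyl ring (a 1.8-fold higher number from compound 1 to compound 4 (0.25 log units; within the scatter)) and the cyclopropyl ring (a 1.6-fold lower number from compound 2 to compound 4 (0.21 log units; within the scatter)), so a ring is not needed here. The high number of compound 3 therefore traces to the amide side, where 4,4-difluoropiperidin-1-yl replaces 4-(trifluoromethyl)piperidin-1-yl (a 20-fold lower number from compound 3 to compound 4 (1.30 log units; beyond the scatter)). No measurement here explains either result. Still open, on these data alone, is how a smaller dimethylamino group or a morpholine ring would behave on the sulfonyl sulfur. Also open, as far as these compounds go, is how an unsubstituted piperidine would behave on the amide.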